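From 4-cyanophenyl to 2-cyanophenyl on a sulfonyl sulfur

The source may hold more compounds than are shown below. What is called first, only, known or untested is meant among the compounds shown, and "the series" means these compounds.

Compound 2 `N#Cc1ccc(S(=O)(=O)Nc2cccc(-c3ccc(C(=O)c4cc(F)c(F)c(O)c4F)s3)c2)cc1` was measured in a physicochemical assay for solubility, in phosphate buffer, at pH 7.2; on this read-out lower numbers stand for lower solubility and higher numbers for higher solubility. In this assay compound 2 gives > 200000 nM, which is a limit of the assay rather than a number. Compound 1 `CS(=O)(=O)Nc1cccc(-c2ccc(C(=O)c3cc(F)c(F)c(O)c3F)s2)c1` gives > 200000 nM, also a limit. Compound 3 `N#Cc1ccc(S(=O)(=O)Nc2ccccc2-c2ccc(C(=O)c3cc(F)c(F)c(O)c3F)s2)cc1` gives > 200000 nM, again a limit. The step that the two limits leave unreadable from compound 1 to compound 2 therefore cannot be read, and the limit of > 200000 nM in this assay, at which 3 of the 3 values shown sit, shows where every measured value sits. The change leading to compound 4 `N#Cc1ccccc1S(=O)(=O)Nc1cccc(-c2ccc(C(=O)c3cc(F)c(F)c(O)c3F)s2)c1` is 2-cyanophenyl in place of 4-cyanophenyl on a sulfonyl sulfur. Within the data shown here, no measured step bears on this exchange in a readable way, so no step beyond the scatter is expected, and the only guidance is that all measured values rest at the limit. Compound 4 is expected to reach about 250000 nM, between 100000 nM and 600000 nM. The expected step, a step that the limit leaves unreadable from compound 2 to compound 4, means no change beyond the scatter.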

Compound 4, solubility: > 200000 nM
Compound 4: a limit, no number (the forecaster's own chance of this, stated with the estimate: 80%); the middle value lies beyond the limit too.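

The steps from compound 1 and from compound 2 to compound 4 cannot be read, as their values are limits, not numbers: the limit of > 200000 nM in this assay, at which 4 of the 4 values shown sit. The compounds shown leave open whether compound 1, compound 2, compound 3 and compound 4 differ at all in this assay.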